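The source may hold more compounds than are shown below. What is called first, only, known or untested is meant among the compounds shown, and "the series" means these compounds.

Working notes on the series. The shared core carries an arylacetylene whose terminal ring is varied: compound 1 `O=C(O)CCc1ccc(C#Cc2ncccc2[N+](=O)[O-])cc1`, compound 2 `O=C(O)CCc1ccc(C#Cc2cccs2)cc1` and compound 3 `O=C(O)CCc1ccc(C#Cc2cncs2)cc1`. In an in vitro functional assay on 1321-N1 cells for agonist activity at Free fatty acid receptor 1 (Homo sapiens), read by fluorescence, spectrophotometry and calcium flux (a higher number here means that more compound is needed for the effect, a lower number that less compound is needed), compound 3 gives 3890 nM, the second highest of the three numbers. Among the compounds with values here, compound 1 gives 11000 nM, a higher number than compound 3; compound 2 gives 251 nM, the lowest number measured, and the only step recorded between neighbouring structures is a 15-fold higher number from compound 2 to compound 3 (1.19 log units; beyond the scatter). Compound 4 `O=C(O)CCc1ccc(C#Cc2ccccn2)cc1` is not yet measured; it differs from compound 3 by pyridin-2-yl in place of 1,3-thiazol-5-yl on a triple-bonded carbon. Within the data shown here, the one step that bears on this change is the exchange of the five-membered ring in a 15-fold higher number from compound 2 to compound 3 (1.19 log units; beyond the scatter), which shows that the terminal ring alone can move the number a long way in this assay. Compound 1 also carries a pyridin-2-yl, but with a nitro group, so it gives no clean comparison. The expectation for compound 4 is a move back toward the lower numbers, a 3.2-fold lower number from compound 3 to compound 4 (0.51 log units; beyond the scatter), and compound 4 is estimated at 1200 nM, with a range from 300 nM to 5000 nM.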

Compound 4, half-maximal effective concentration: 13200 nM
Compound 4: the middle estimate sits 11-fold (1.04 log units) below what was measured, outside the stated range (above it).
By their numbers in this assay, from the lowest: compound 2; then compound 3; then compounds 1 and 4 (each within the scatter of the next).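

In this assay, pyridin-2-yl on the triple-bonded carbon does not bring the number back down (in fact a 3.4-fold higher number from compound 3 to compound 4 (0.53 log units; beyond the scatter)), and against the thiophen-2-yl analogue the change is far larger (a 53-fold higher number from compound 2 to compound 4 (1.72 log units; beyond the scatter)). Among compounds 2, 3 and 4, both terminal rings holding a ring nitrogen therefore give higher numbers than thiophen-2-yl, with no compound here going against this. The nitro group of compound 1 also proves to matter little on this ring (hydrogen in its place gives a 1.2-fold higher number from compound 1 to compound 4 (0.08 log units; within the scatter)), so compound 1 and compound 4 read as one level.

No measurement at hand explains why these terminal rings differ. Open, on these data alone, is whether a plain phenyl ring on the triple-bonded carbon falls with thiophen-2-yl or with pyridin-2-yl, and whether a methyl or a chlorine on the thiophene ring keeps its low number.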